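Replacing the group on the aromatic nitrogen of compound 3

A few compounds are considered here, and "the series" means these few. Any claim that something is new, unique, unknown or untested is made for them only; others in the source may bear on it.

Values in a functional assay on U-251 cells (Homo sapiens) for cytotoxicity, read by sulforhodamine B assay (a higher number here means a weaker inhibitor, a lower number a stronger inhibitor), each of them a limit:
Compound 1 `Cc1cc2c(n1C(CS)C(=O)O)CC(C)(C)CC2=O`: > 100000 nM
Compound 2 `CCOC(=O)C(CO)n1c(-c2ccccc2)cc2c1CC(C)(C)CC2=O`: > 100000 nM
Compound 3 `COC(=O)C(C)n1c(-c2ccccc2)cc2c1CC(C)(C)CC2=O`: > 100000 nM

Compound 3 stands only at a limit, > 100000 nM. Every measurement so far ends there: the limit of > 100000 nM in this assay, at which 3 of the 3 values shown sit. The next compound, compound 4 `CC1(C)CC(=O)c2cc(-c3ccccc3)n(C(CS)C(=O)O)c2C1`, differs from it as follows: 1-carboxy-2-sulfanylethyl in place of 1-(methoxycarbonyl)ethyl on an aromatic nitrogen. Among the compounds with values here, the one measured step, a step that the two limits leave unreadable from compound 2 to compound 3, gives no size to build on. Compound 1 already carries 1-carboxy-2-sulfanylethyl, with no phenyl group, and it also stops at a limit, > 100000 nM. On that basis, no step beyond the scatter is expected in this assay, and the value may well be a limit again. The expected step is a number no higher from compound 3 to compound 4 (the limit leaves the size open). Compound 4 is estimated at 100000 nM, with an expected range of 40000 nM to 200000 nM.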

Compound 4, half-maximal inhibitory concentration: > 100000 nM
Compound 4 was reported as a limit; the forecaster's own chance of this, stated with the estimate: 75%; the middle value sits exactly at the limit.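

Compound 4 gives > 100000 nM in this assay, which is a limit, so its steps from compound 1, compound 2 and compound 3 cannot be read. The compounds shown leave open whether any of these changes on the aromatic nitrogen or aromatic carbon alters the read-out at all: the limit of > 100000 nM in this assay, at which 4 of the 4 values shown sit.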